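This account rests on a few compounds, and the source may have more. Where it says the series, first, only, none or still open, it means among the compounds named here.

Measured compounds in an ADME assay on Raji cells (Homo sapiens) for cytotoxicity, with a stated time of 72 h; a lower number here means that less compound is needed, a higher number that more compound is needed for the effect:
compound 1 `Cc1ccc(-c2nc3ccccc3s2)cc1NC(=O)c1cc([N+](=O)[O-])c(N2CCC(C(=O)O)CC2)cc1Cl` gives > 25000 nM, a limit of the assay.
compound 2 `O=C(Nc1cccc(-c2ccccc2)c1)c1cc([N+](=O)[O-])ccc1Cl` gives > 27000 nM, a limit of the assay.
compound 3 `COc1ccc(-c2nc3ccccc3s2)cc1NC(=O)c1cc([N+](=O)[O-])c(N2CCC(C(=O)O)CC2)cc1Cl` gives > 25000 nM, a limit of the assay.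

Compound 1 thus stands only at a limit in this assay, and all three values shown are limits, so no ordering among them can be read. Going by the values given here, the one measured step, a step that the two limits leave unreadable from compound 1 to compound 3, is left unreadable by the two limits (the limit of > 25000 nM in this assay, at which 2 of the 3 values shown sit).

Compound 4 `COC(=O)C1CCN(c2cc(Cl)c(C(=O)Nc3cc(-c4nc5ccccc5s4)ccc3C)cc2[N+](=O)[O-])CC1` differs from compound 1 by methyl in place of hydrogen on an oxygen next to a carbonyl group. No measured step touches this position, so nothing shown bears on it; what is shown is that every compound in the series sits at a limit of > 25000 nM in this assay, at which 2 of the 3 values shown sit (the limit of > 27000 nM in this assay, at which 1 of the 3 values shown sits). No step beyond the scatter is therefore expected, with the estimated step of a number no higher from compound 1 to compound 4 (the limit leaves the size open). Compound 4 is expected to give 25000 nM in this assay, within 12000 nM to 60000 nM, most likely again reported only as a limit.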

Compound 4, half-maximal effective concentration: > 25000 nM
Compound 4 was reported as a limit; the forecaster's own chance of this, stated with the estimate: 80%; the middle value lies on the limit itself.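

Compound 4 gives > 25000 nM in this assay, a limit of the assay; with compound 1 also at a limit, no step can be read between them. The compounds shown leave open whether carboxy and methoxycarbonyl differ at all in this assay, since none has a value beyond a limit.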